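A Small Expected Step from Compound 1

The compounds below may be only part of what the source reports. "The series", "measured", "known", "first", "only" and "open" are said of these compounds alone.

Of the compounds shown here, three built on a shared core have been tested. In an ADME assay on HEL cells (Homo sapiens) for cytotoxicity (on this read-out higher numbers stand for lower toxicity in this test and lower numbers for higher toxicity in this test), compound 1 `O=C(COc1cccc2ccccc12)N/N=C/c1ccccc1Br` gives 100 ug/mL and compound 2 `COc1ccc(OC)c(/C=N/NC(=O)COc2cccc3ccccc23)c1` gives 56.9 ug/mL while compound 3 `COc1cc(/C=N/NC(=O)COc2cccc3ccccc23)cc(OC)c1O` gives 52.8 ug/mL so compound 1 stands within the usual scatter of both others.

Compound 4 `CSc1ccc(/C=N/NC(=O)COc2cccc3ccccc23)cc1` is still unmeasured. It carries 4-(methylsulfanyl)phenyl in place of 2-bromophenyl on a carbon with a double bond to nitrogen.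

Within the data shown here, no measured pair differs in one place only. Still, compound 3 at 52.8 ug/mL and compound 1 at 100 ug/mL carry different groups there and stay within the scatter, so no step beyond the scatter is expected in this assay and the estimate is a 1.7-fold lower number from compound 1 to compound 4 (0.22 log units; within the scatter) only.

Compound 4 is estimated at 60 ug/mL (expected range 30 ug/mL to 110 ug/mL).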

Compound 4, half-maximal cytotoxic concentration: > 100 ug/mL
Compound 4: no number, only a limit; the forecaster's own chance of this, stated with the estimate: 25%; at least 1.6-fold (0.22 log units) between middle value and limit.
By their numbers in this assay, from the lowest: compounds 3, 2 and 1 (each within the scatter of the next).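

In this assay, compound 4 gives > 100 ug/mL, which is a limit of the assay and not a number. Among these compounds, putting 4-(methylsulfanyl)phenyl in place of 2-bromophenyl on a carbon with a double bond to nitrogen gives the first step here that changes one place only: a number no lower from compound 1 to compound 4 (the limit leaves the size open). How large this step is cannot be read because the read-out ends at a limit: the limit of > 100 ug/mL in this assay, at which 1 of the 4 values shown sits.

What the compounds shown leave open is how an amine or a carboxylic acid would read at this place.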